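The compounds below may be only part of what the source reports. "The series", "measured", "known", "first", "only" and "open" are said of these compounds alone.

Of the compounds shown here, three sharing one core have been measured in a functional assay on MKN-45 cells (Homo sapiens) for cytotoxicity, read by MTT assay, with a stated time of 72 h; on this read-out lower numbers stand for stronger inhibition and higher numbers for weaker inhibition. Compound 1 `CN(C)CCCNc1nc(-c2ccc(NC(=O)Nc3ccccc3F)cc2)nc2ccsc12` gives 730 nM in this assay. Compound 2 `CN(C)CCNc1nc(-c2ccc(NC(=O)Nc3ccccc3F)cc2)nc2ccsc12` gives 530 nM, and compound 3 `CN(C)CCNc1nc(-c2ccc(NC(=O)Nc3ccc(Cl)cc3Cl)cc2)nc2ccsc12` gives 2360 nM. The first step alters the saturated chain: a 1.4-fold lower number from compound 1 to compound 2 (0.14 log units; within the scatter). The second step replaces the group on the amide-type nitrogen: a 4.5-fold higher number from compound 2 to compound 3 (0.65 log units; beyond the scatter). Compound 2 thus carries the lowest of the three numbers, though its gap to compound 1 is within the scatter, so only compound 3 stands clearly apart from it.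

Compound 4 `CCN(CC)CCNc1nc(-c2ccc(NC(=O)Nc3ccccc3F)cc2)nc2ccsc12` differs from compound 2 in a single place: diethylamino in place of dimethylamino on a saturated chain carbon, two bonds along the chain from a nitrogen on an aromatic ring. Only the step from compound 1 to compound 2 touches the same saturated chain, and that step stayed within the scatter; no measured step changes what sits on that chain nitrogen itself, so nothing shown points to a large effect in either direction. The step in this assay from compound 2 to compound 4 is therefore expected to be small, with no clear direction, a 1.1-fold higher number from compound 2 to compound 4 (0.05 log units; within the scatter). Compound 4 is estimated to give 600 nM in this assay, within a range from 250 nM to 1500 nM.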

Compound 4, half-maximal inhibitory concentration: 1040 nM
For compound 4 the middle estimate is 1.7-fold (0.24 log units) below the measured one, within the range that was stated.
By their numbers in this assay, from the lowest: compounds 2, 1 and 4 (each within the scatter of the next); then compound 3.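

Going by these compounds alone, compound 4 is the first compound here in which the groups on the chain nitrogen themselves change, and in this assay swapping dimethylamino for diethylamino, which goes from 3 to 5 heavy atoms, gives a 2.0-fold higher number from compound 2 to compound 4 (0.29 log units; within the scatter) and so no clear difference. The comparison with the other chain gives a 1.4-fold higher number from compound 1 to compound 4 (0.15 log units; within the scatter) as well, so compound 1, compound 2 and compound 4 cannot be told apart by these numbers. At this end of the molecule, neither the change in the chain nor the move to diethylamino has left the scatter, which so far only the change on the amide-type nitrogen has done, with a 4.5-fold higher number from compound 2 to compound 3 (0.65 log units; beyond the scatter) as its step.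

Nothing shown offers a measured reason for any of these numbers. From the compounds shown here alone, it remains open whether a ring amine such as pyrrolidine or morpholine, or a primary amine, at the end of the chain would also stay within the scatter, and whether diethylamino would behave the same way on the longer chain of compound 1.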